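The compounds below may be only part of what the source reports. "The series", "measured", "known", "first", "only" and "open" are said of these compounds alone.

Compound 3 `CCOC(=O)c1cc2ccc(OCCCCCn3cc(CNC(=O)CCCCC4CCSS4)nn3)cc2oc1=O` was tested in a functional assay on PC-12 cells (Rattus norvegicus) for cytotoxicity, read by MTT assay, with stated times of 3 h and 2 h, tested at 0.1 uM (on this read-out lower numbers stand for a weaker effect and higher numbers for a stronger effect at the one concentration tested), and gave 34.4%. Compound 2 `CC(=O)c1cc2ccc(OCCCn3cc(CNC(=O)CCCCC4CCSS4)nn3)cc2oc1=O` gives 34.6% and compound 1 `O=C(CCCCC1CCSS1)NCc1cn(CCCOc2ccc3ccc(=O)oc3c2)nn1` gives 37.8%; both numbers lie within the usual scatter of the number for compound 3, so the three compounds cannot be told apart on this read-out. Compound 4 `COc1ccc(-c2cc3ccc(OCCCCCn4cc(CNC(=O)CCCCC5CCSS5)nn4)cc3oc2=O)cc1` differs from compound 3 in one place: 4-methoxyphenyl in place of ethoxycarbonyl on an aromatic carbon. Among the compounds with values here, the only measured step that bears on this, a change of a group on an aromatic carbon of the shared core, was a number 3.2 percentage points lower from compound 1 to compound 2 (within the scatter). Replacing one group with another at the aromatic core is therefore expected to move the number little, with a number 0.4 percentage points lower from compound 3 to compound 4 (within the scatter) staying inside the scatter. Compound 4 is expected to give 34%, between 26% and 42%.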

Compound 4, a percentage reported as activity, at one concentration (the size of the read-out at that concentration, not a potency): 34.5%
Compound 4: the middle estimate sits 0.5 percentage points below what was measured; the range from low to high includes it.
By their numbers in this assay, from the lowest: compounds 3, 4, 2 and 1 (each within the scatter of the next).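

Putting 4-methoxyphenyl in place of ethoxycarbonyl on this aromatic carbon gives, in this assay, a number 0.1 percentage points higher from compound 3 to compound 4 (within the scatter). The earlier step concerned only acetyl and hydrogen, whereas this one brings in a six-membered aromatic ring of carbon only and still produces no difference that can be read. Nothing measured here explains why the number holds steady. From the compounds shown here alone, it remains open whether an amine or a carboxylic acid at this position would move the number beyond the scatter. Going by these compounds, whether these compounds would separate at other concentrations also remains open.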